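The source may report more compounds than this note shows. Statements on the series, on what has been measured and on what is new or still open speak of the compounds shown alone.

In an ADME assay on J774.A1 cells (Mus musculus) for cytotoxicity, read by MTT assay, with a stated time of 72 h (on this read-out higher numbers stand for an effect only at larger amounts of compound and lower numbers for an effect already at smaller amounts), compound 3 `CCOC(=O)CNc1nc(NC(C)C)nc2ccccc12` gives > 33000 nM as a limit of the assay and not a number. Compound 2 `OCCNc1nc(NCc2ccco2)c2ccccc2n1` gives > 33000 nM as a limit too. Among the measured compounds shown here, compound 1 `CC(C)Nc1nc(NCc2ccco2)c2ccccc2n1` gives 17000 nM as the only actual number so far. Compound 4 `CC(C)Nc1nc(N(C)C)c2ccccc2n1` carries dimethylamino in place of ((ethoxycarbonyl)methyl)amino on an aromatic carbon and keeps the isopropylamino group. The closest measured step is an at least 1.9-fold higher number from compound 1 to compound 3 (0.28 log units; that floor lies within the scatter) and involves the same substituent, while an at least 1.9-fold higher number from compound 1 to compound 2 (0.28 log units; that floor lies within the scatter) is the other measured step. Both are small floors, so only a modest shift towards a lower number is expected. The estimated step is an at least 1.6-fold lower number from compound 3 to compound 4 (0.21 log units; that floor lies within the scatter) and may not exceed the scatter. Compound 4 is expected at 20000 nM with a range of 8000 nM to 40000 nM.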

Compound 4, half-maximal effective concentration: > 33000 nM
Compound 4: only a limit was reported (the forecaster's own chance of this, stated with the estimate: 35%); at least 1.6-fold (0.21 log units) between middle value and limit.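

In this assay, dimethylamino in place of ((furan-2-yl)methyl)amino on this aromatic carbon gives an at least 1.9-fold higher number from compound 1 to compound 4 (0.28 log units; that floor lies within the scatter). The isopropylamino group stays the same, and this position now carries a group with 0 hydrogen-bond donors, with no sign of a lower number than that of compound 1. The step between compound 3 and compound 4 cannot be read because both values are limits of the assay: the limit of > 33000 nM in this assay, at which 3 of the 4 values shown sit.

The compounds shown leave open how far these compounds lie beyond that limit. They also leave open whether an unsubstituted amine or a longer chain on this carbon would give a readable number.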